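This account rests on a few compounds, and the source may have more. Where it says the series, first, only, none or still open, it means among the compounds named here.

Measured so far in a functional assay on HCT-116 cells (Homo sapiens) for antiproliferative activity, read by MTT assay, with a stated time of 72 h; a higher number here means a weaker inhibitor, a lower number a stronger inhibitor:
Compound 1 `O=C(CCc1cccc2c1B(O)OC2)Nc1ccccc1` gives 350 nM
Compound 2 `C#Cc1ccc(NC(=O)CCc2cccc3c2B(O)OC3)cc1` gives 45000 nM

Compound 1 holds the lower of these two numbers, which makes it the stronger inhibitor of the pair. Compound 3 `O=C(CCc1cccc2c1B(O)OC2)Nc1cccc(-c2cccc(Cl)c2)c1` keeps the core of compound 1 and puts 3-chlorophenyl in place of hydrogen on an aromatic carbon, meta to a large group (3-chlorophenyl in place of hydrogen on an aromatic carbon). Going by the values given here, one measured step bears on this change, the replacement of hydrogen on an aromatic carbon by ethynyl in compound 2 (a 130-fold higher number from compound 1 to compound 2 (2.11 log units; beyond the scatter)), and that step is large. It is a single case with a different group, so it suggests a direction more than a size. In this assay the step expected and estimated here is an 11-fold higher number from compound 1 to compound 3 (1.06 log units; beyond the scatter) and would stay short of that measured step. Compound 3 is estimated at 4000 nM (expected range 600 nM to 30000 nM).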

Compound 3, half-maximal inhibitory concentration: 350 nM
For compound 3 the middle estimate is 11-fold (1.06 log units) above the measured one; measured number below the stated range.
By their numbers in this assay, from the lowest: compounds 1 and 3 (each within the scatter of the next); then compound 2.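

In this assay, putting 3-chlorophenyl in place of hydrogen on an aromatic carbon, meta to a large group, gives no change at the digits printed from compound 1 to compound 3 (within the scatter). This shows that a hydrogen on this ring of the core of compound 1 can give way to a group of 7 heavy atoms with no step beyond the scatter, so the large step seen earlier, a 130-fold higher number from compound 1 to compound 2 (2.11 log units; beyond the scatter), does not hold for every replacement of hydrogen on this ring. Nothing available accounts for the difference between these two steps.

The compounds shown leave open whether a smaller group at this same place, such as an amine or a carboxylic acid, would behave like 3-chlorophenyl. They also leave open how much the chlorine itself contributes, which a plain phenyl group at this place would address.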